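The source may hold more compounds than are shown below. What is called first, only, known or untested is meant among the compounds shown, and "the series" means these compounds.

Compound 1, `COc1ccc(SCc2ccc(/C=C/C(=O)Nc3ccccc3N)cc2)cc1OC`, is the starting point of this comparison. In a functional assay on A549 cells (Homo sapiens) for inhibition, read by CCK-8 assay, with a stated time of 72 h, tested at 2 uM (a lower number here means less inhibition of growth, a higher number more inhibition of growth at the concentration tested), compound 1 gives 65.5%, the second highest of the three numbers at hand. The nearest neighbour is compound 3, `Nc1ccccc1NC(=O)c1ccc(CSc2nccc(C(F)(F)F)n2)cc1`, which in this assay gives 75.4%, a difference within the scatter; the furthest is compound 2, `Nc1ccccc1NC(=O)c1ccc(CSc2cccc(F)c2)cc1`, which in this assay gives 46.9%, a gap beyond the scatter. The unmeasured compound 4, `Nc1ccccc1NC(=O)/C=C/c1ccc(CSCCc2ccccc2)cc1`, differs from compound 1 by a single change: phenethyl in place of 3,4-dimethoxyphenyl on a sulfur. Among the compounds with values here, no pair of measured compounds shows this kind of exchange, so the expected step in this assay is modest and possibly not beyond the scatter, with a slight lean downward. On that basis compound 4 is expected to give 58% in this assay, within a range from 38% to 76%, which amounts to an estimated step of a number 7.5 percentage points lower from compound 1 to compound 4 (within the scatter).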

Compound 4, percent growth inhibition at one concentration: 45.7%
The estimate for compound 4 lay 12.3 percentage points above the measured number; measured number inside the range.
By their numbers in this assay, from the lowest: compounds 4 and 2 (each within the scatter of the next); then compounds 1 and 3 (each within the scatter of the next).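

Phenethyl in place of 3,4-dimethoxyphenyl on a sulfur gives a number 19.8 percentage points lower from compound 1 to compound 4 (beyond the scatter) in this assay, the first step here that can be read at a single place. Within the data shown here, it shows that growth inhibition at this concentration responds to what this sulfur carries, which the earlier compounds, differing in more than one place, could not show. Nothing measured here accounts for the step.

On these data alone, it remains open whether the step follows from losing the two methoxy groups or from gaining the chain of phenethyl. A plain phenyl or a benzyl on that sulfur would separate the two.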